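Swapping the triazole aryl group: from compound 3 to compound 4

The source may hold more compounds than are shown below. What is called first, only, known or untested is meant among the compounds shown, and "the series" means these compounds.

The series shares one core and varies only the aryl group on the triazole nitrogen. In a functional assay on A549 cells (Homo sapiens) for inhibition, read by sulforhodamine B assay, with a stated time of 48 h, tested at 50 uM (a lower number here means less inhibition of growth, a higher number more inhibition of growth at the concentration tested), compound 1 `COc1ccc([C@@H]2C/C(=N/OCc3cn(-c4ccc(C#N)cc4)nn3)c3cc(CC=C(C)C)c(OC)cc3O2)cc1` gives 42%, and compound 2 `COc1ccc([C@@H]2C/C(=N/OCc3cn(-c4ccc(Cl)cc4C)nn3)c3cc(CC=C(C)C)c(OC)cc3O2)cc1` gives 35%; the step of a number 7 percentage points lower from compound 1 to compound 2 (within the scatter) separates them. Compound 3 `COc1ccc([C@@H]2C/C(=N/OCc3cn(-c4ccccc4CO)nn3)c3cc(CC=C(C)C)c(OC)cc3O2)cc1` stands highest of the three, giving 100% in this assay, with the nearest value that of compound 1 and the furthest that of compound 2.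

Compound 4 `COc1ccc([C@@H]2C/C(=N/OCc3cn(-c4ccc(NC(C)=O)cc4)nn3)c3cc(CC=C(C)C)c(OC)cc3O2)cc1` is the next step. The change is 4-acetamidophenyl in place of 2-(hydroxymethyl)phenyl on an aromatic nitrogen. Within the data shown here, the steps that bear on it run the other way: a number 58 percentage points higher from compound 1 to compound 3 (beyond the scatter) and a number 65 percentage points higher from compound 2 to compound 3 (beyond the scatter), both large. Compound 4 carries its group in the same pattern as compound 1, so the account expects the gain seen in compound 3 to be largely given back, a large step downward in this assay, estimated as a number 50 percentage points lower from compound 3 to compound 4 (beyond the scatter). For compound 4 the expected value in this assay is 50%, with a range from 25% to 85%.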

Compound 4, percent growth inhibition at one concentration: 19%
Estimate against measurement, compound 4: 31 percentage points above, outside the stated range (below it).
By their numbers in this assay, from the lowest: compound 4; then compounds 2 and 1 (each within the scatter of the next); then compound 3.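

Compound 4 is the lowest of the four in this assay, lying clearly under both other aryl groups, with a number 23 percentage points lower from compound 1 to compound 4 (beyond the scatter) and a number 16 percentage points lower from compound 2 to compound 4 (beyond the scatter), so acetamido in place of cyano on the same ring takes the value further down rather than leaving it level. The large a number 81 percentage points lower from compound 3 to compound 4 (beyond the scatter) also shows that the count of hydrogen-bond donors and acceptors does not account for the value at this position, since 2-(hydroxymethyl)phenyl and 4-acetamidophenyl have the same counts. No measurement given here explains these differences.

The compounds shown leave open whether the high value of compound 3 depends on the hydroxymethyl group itself or on where it sits on the ring. On these data alone, how an aminomethyl or a methoxymethyl group would read at this position also remains unknown.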